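The compounds below may be only part of what the source reports. "The series", "measured", "known", "first", "only" and "open" are said of these compounds alone.

Measured so far:
compound 1 `O=C1Nc2ccc(C(=O)c3ccco3)cc2/C1=C/c1cc(Br)c(O)c(Br)c1`: 65%
compound 2 `Cc1cc(/C=C2\C(=O)Nc3ccc(C(=O)c4ccco4)cc32)cc(C)c1O`: 9%

Compound 2 stands lowest of the two numbers in an assay on HeLa cells for inhibition of Kinesin-like protein KIF15 (Homo sapiens), read by microscopy, with stated times of 2 s and 20 s, tested at 750 nM; a higher number here means more inhibition at the concentration tested (going by the name of the read-out), a lower number less inhibition; its nearest neighbour is compound 1, and the step of a number 56 percentage points lower from compound 1 to compound 2 (beyond the scatter) is large and beyond the scatter. Compound 3 `COc1ccc(/C=C2\C(=O)Nc3ccc(C(=O)c4ccco4)cc32)cc1Br` is the next variation on the same core, differing from compound 2 by 3-bromo-4-methoxyphenyl in place of 4-hydroxy-3,5-dimethylphenyl on a double-bonded chain carbon bound to a double-bonded ring carbon. Among the compounds with values here, the only measured step that bears on it is the one from compound 1 to compound 2, which shows that the aryl group on the double-bonded chain carbon governs most of the range seen. Within the data shown here, compound 3 brings one bromine back into that ring but gives up the hydroxyl, and no measured step covers the methoxy, so the direction is expected to be upward from compound 2, with wide uncertainty. For compound 3 the expected step is a number 21 percentage points higher from compound 2 to compound 3 (beyond the scatter). Compound 3 is estimated at 30%, in the range 5% to 60%.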

Compound 3, a percentage reported as inhibition, at one concentration (the size of the read-out at that concentration, not a potency): 2.3%
Compound 3: the middle estimate sits 27.7 percentage points above what was measured; the measured number lies below the stated range.
By their numbers in this assay, from the lowest: compounds 3 and 2 (each within the scatter of the next); then compound 1.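

In this assay, exchanging 4-hydroxy-3,5-dimethylphenyl for 3-bromo-4-methoxyphenyl on a double-bonded chain carbon bound to a double-bonded ring carbon gives a number 6.7 percentage points lower from compound 2 to compound 3 (within the scatter), so these two groups are not told apart at this position. Exchanging 3,5-dibromo-4-hydroxyphenyl for the same 3-bromo-4-methoxyphenyl gives a number 62.7 percentage points lower from compound 1 to compound 3 (beyond the scatter), so a bromine on this ring does not by itself go with the high number of compound 1, and among the three groups shown only 3,5-dibromo-4-hydroxyphenyl stands apart. No measurement offered here accounts for this difference.

As far as these compounds go, whether the high number of compound 1 depends on the pair of bromines, on the hydroxyl or on both together stays open. Also open, from the compounds shown here alone, is how a chlorine or an amine on this ring would read in this assay.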